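A Bromine Added to the Phenyl Ring of Compound 1

The source may report more compounds than this note shows. Statements on the series, on what has been measured and on what is new or still open speak of the compounds shown alone.

Among the measured compounds shown here, compound 1 `CC(c1ccc(-c2ccccc2)c(F)c1)c1nnc2n1N=C(c1ccccc1)CS2` is one of two compounds measured in a functional assay on Huh-7 cells (Homo sapiens) for inhibition, read by sulforhodamine B assay, with a stated time of 72 h; a higher number here means a weaker inhibitor, a lower number a stronger inhibitor. Compound 1 gives 6700 nM, the lower of the two numbers, though within the scatter of the other. Compound 2 `CC(C)Cc1ccc(C(C)c2nnc3n2N=C(c2ccc(Cl)cc2Cl)CS3)cc1` gives 7500 nM in this assay, so the two cannot be told apart. Compound 3 `CC(c1ccc(-c2ccccc2)c(F)c1)c1nnc2n1N=C(c1ccc(Br)cc1)CS2` has not yet been measured. It differs from compound 1 in one place: bromo in place of hydrogen on an aromatic carbon, so that the phenyl becomes 4-bromophenyl. For the measured compounds named here, no measured pair shows what this single change does, and compound 2 differs from compound 1 in several places at once, so its value gives no guidance on direction. The step of a 1.2-fold lower number from compound 1 to compound 3 (0.09 log units; within the scatter) is therefore expected to be small, with no direction beyond the scatter. Compound 3 is expected to give about 5500 nM, within a range from 2000 nM to 15000 nM.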

Compound 3, half-maximal inhibitory concentration: 5000 nM
For compound 3 the middle estimate is 1.1-fold (0.04 log units) above the measured one; the measured number falls inside the stated range.
By their numbers in this assay, from the lowest: compounds 3, 1 and 2 (each within the scatter of the next).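

In this assay, going from phenyl to 4-bromophenyl gives a 1.3-fold lower number from compound 1 to compound 3 (0.13 log units; within the scatter), so compound 1 and compound 3 cannot be told apart. Among the compounds shown here, this is the first direct reading of a change at this place, para to a large group: in this one pair, a single bromine atom in place of hydrogen leaves no effect that rises above the scatter. Nothing available explains this result or shows what the bromine does in the cells.

As far as these compounds go, whether a different group at this place, such as an amine, a methoxy group or a carboxylic acid, would move the number beyond the scatter remains open. Also open, from the compounds shown here alone, is whether bromo in place of hydrogen would give a similar step on a compound with a different remainder, such as compound 2.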